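The source may hold more compounds than are shown below. What is called first, only, known or untested is meant among the compounds shown, and "the series" means these compounds.

Measured in a functional assay on MKN-45 cells (Homo sapiens) for cytotoxicity, read by MTT assay, with a stated time of 72 h; on this read-out higher numbers stand for weaker inhibition and lower numbers for stronger inhibition:
compound 1, `COc1cc2c(Oc3ccc(NC(=O)c4nn(-c5ccc(Br)cc5)c(=O)c5ccccc45)cc3F)ccnc2cc1OCCCN1CCCC1`: 230 nM
compound 2, `COc1cc2c(Oc3ccc(NC(=O)c4nn(-c5ccccc5Br)c(=O)c5ccccc45)cc3F)ccnc2cc1OCCCN1CCCC1`: 410 nM
compound 3, `COc1cc2c(Oc3ccc(NC(=O)c4nn(-c5ccc(Br)cc5)c(=O)c5ccccc45)cc3F)ccnc2cc1OCCCN1CCC(C)CC1`: 330 nM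

Compound 4, `COc1cc2c(Oc3ccc(NC(=O)c4nn(-c5ccccc5Br)c(=O)c5ccccc45)cc3F)ccnc2cc1OCCCN1CCC(C)CC1`, awaits measurement in this assay. Compound 4 differs from compound 3 by 2-bromophenyl in place of 4-bromophenyl on an aromatic nitrogen. The same change has already been made once, from compound 1 to compound 2: 2-bromophenyl in place of 4-bromophenyl on an aromatic nitrogen. In this assay that pair gave a 1.8-fold higher number from compound 1 to compound 2 (0.25 log units; within the scatter). The cores of compound 1 and compound 3 differ by 4-methylpiperidin-1-yl in place of pyrrolidin-1-yl on a saturated chain carbon, three bonds along the chain from an oxygen on an aromatic ring, and in this assay that pair gave a 1.4-fold higher number from compound 1 to compound 3 (0.16 log units; within the scatter). The surroundings of the change are the same word for word in both pairs, so it counts as the same change.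

In this assay the step to compound 4 is expected to be a 1.7-fold higher number from compound 3 to compound 4 (0.22 log units; within the scatter), because a 1.8-fold higher number from compound 1 to compound 2 (0.25 log units; within the scatter) remained within the scatter. Compound 4 is therefore expected near 550 nM, with a likely span from 280 nM to 1100 nM.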

Compound 4, half-maximal inhibitory concentration: 510 nM
Estimate against measurement, compound 4: 1.1-fold (0.03 log units) above; low and high end bracket the measured number.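

Carried onto the 4-methylpiperidin-1-yl core in this assay, 2-bromophenyl in place of 4-bromophenyl gives a 1.5-fold higher number from compound 3 to compound 4 (0.19 log units; within the scatter), which agrees with the earlier step: the same change on two cores in this assay, a 1.8-fold higher number (0.25 log units; within the scatter) from compound 1 to compound 2 and a 1.5-fold higher number (0.19 log units; within the scatter) from compound 3 to compound 4, 1.2-fold (0.06 log units) apart, within the scatter of two such steps. Likewise, 4-methylpiperidin-1-yl in place of pyrrolidin-1-yl on the 2-bromophenyl core gives a 1.2-fold higher number from compound 2 to compound 4 (0.09 log units; within the scatter), which also agrees with the earlier step: the same change on two cores in this assay, a 1.4-fold higher number (0.16 log units; within the scatter) from compound 1 to compound 3 and a 1.2-fold higher number (0.09 log units; within the scatter) from compound 2 to compound 4, 1.2-fold (0.06 log units) apart, within the scatter of two such steps. Each change therefore reads alike on the two cores compared, but every step lies within the scatter, so the data do not show that either change has a real effect or that this agreement extends to other cores.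

Still open, going by these compounds, is whether a plain phenyl or a 4-methoxyphenyl in place of the bromophenyl would move the number beyond the scatter. The same question stands for morpholine or dimethylamine in place of pyrrolidin-1-yl.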